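The source may report more compounds than this note shows. Statements on the series, on what has been measured and on what is new or still open speak of the compounds shown alone.

In a functional assay on DU-145 cells (Homo sapiens) for cytotoxicity, read by ELISA, with a stated time of 2 days (a lower number here means a stronger inhibitor, a higher number a weaker inhibitor), compound 1 (`Oc1ccc(-c2cc(-c3ccccc3)cc(-c3ccsc3)n2)cc1`) gives 8500 nM and compound 2 (`Oc1cccc(-c2cc(-c3ccccc3)nc(-c3ccccc3)c2)c1`) gives 17900 nM. Compound 2 therefore has the higher number of the two and is the weaker inhibitor, with a gap beyond the usual scatter. Compound 3 (`Oc1cccc(-c2cc(-c3ccccc3)nc(-c3ccccn3)c2)c1`) departs from compound 2 in one place: pyridin-2-yl stands in place of phenyl on an aromatic carbon, next to the ring nitrogen (pyridin-2-yl in place of phenyl on an aromatic carbon). Among the measured compounds shown here, the two measured compounds differ in more than one place, so no measured step isolates this swap and the expectation rests on thin evidence. The expected change is small, an estimated 1.5-fold lower number from compound 2 to compound 3 (0.17 log units; within the scatter), leaning towards a lower number but not beyond the scatter in this assay. For compound 3 the expected value is 12000 nM, with an estimated range from 4000 nM to 35000 nM.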

Compound 3, half-maximal inhibitory concentration: 15500 nM
The estimate for compound 3 lay 1.3-fold (0.11 log units) below the measured number; measured number inside the range.
By their numbers in this assay, from the lowest: compounds 1, 3 and 2 (each within the scatter of the next, the first and the last beyond it).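

In this assay, among the compounds shown here, putting pyridin-2-yl in place of phenyl on this aromatic carbon, next to the ring nitrogen, gives a 1.2-fold lower number from compound 2 to compound 3 (0.06 log units; within the scatter), the first step that isolates a single change. The step lies within the usual scatter, so a ring nitrogen entering at this place, with the heavy-atom count unchanged and one hydrogen-bond acceptor added, leaves compound 2 and compound 3 indistinguishable here. No independent measurement is available to account for this result.

The compounds shown leave open how an amine, a carboxylic acid or a longer alkyl chain would read at this carbon, since only six-membered aromatic rings have been compared there. Compound 1 still differs from compound 2 in more than one place, so the source of their gap also remains unresolved.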